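This account rests on a few compounds, and the source may have more. Where it says the series, first, only, none or still open, it means among the compounds named here.

Compound 3 `Cc1cccc2sc(NC(=O)CCN3CCN(CC4CCCO4)CC3)nc12` gives 109 nM in an assay on membranes from brain for displacement of a labelled ligand from Sigma non-opioid intracellular receptor 1 (Cavia porcellus), read by scintillation counting, with a stated time of 120 min (a lower number here means a stronger inhibitor, a higher number a weaker inhibitor), the lowest of the three numbers shown. Compound 1 `CCCCN1CCN(CCC(=O)Nc2nc3c(C)cccc3s2)CC1` gives 204 nM, and the step of a 1.9-fold lower number from compound 1 to compound 3 (0.27 log units; within the scatter) lies within the scatter. Compound 2 `Cc1cccc2sc(NC(=O)CCN3CCN(CCN(C)C)CC3)nc12` gives 1000 nM, and the step of a 9.2-fold lower number from compound 2 to compound 3 (0.96 log units; beyond the scatter) is beyond it. Compound 4 `Cc1cccc2sc(NC(=O)CCN3CCN(c4ccccn4)CC3)nc12` carries pyridin-2-yl in place of (oxolan-2-yl)methyl on an amine nitrogen in a ring. Both measured steps, a 1.9-fold lower number from compound 1 to compound 3 (0.27 log units; within the scatter) and a 9.2-fold lower number from compound 2 to compound 3 (0.96 log units; beyond the scatter), alter the same ring amine nitrogen, and only the change to a group bearing a second amine shifted the number beyond the scatter. With no aromatic group at this place among the measured compounds, the step of a 1.5-fold higher number from compound 3 to compound 4 (0.17 log units; within the scatter) is expected to stay near compound 3. Compound 4 is therefore estimated at 160 nM, within 45 nM to 600 nM.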

Compound 4, inhibition constant: 1000 nM
Compound 4: middle estimate off by 6.3-fold (0.80 log units), on the low side; the whole stated range lies below it.
By their numbers in this assay, from the lowest: compounds 3 and 1 (each within the scatter of the next); then compounds 2 and 4 (each within the scatter of the next).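

In this assay, among the compounds shown here, the change to pyridin-2-yl gives a 9.2-fold higher number from compound 3 to compound 4 (0.96 log units; beyond the scatter) and a 4.9-fold higher number from compound 1 to compound 4 (0.69 log units; beyond the scatter) on this ring amine nitrogen, so a group bearing a second amine is no longer the only one that moves the number beyond the scatter. The two such groups are not told apart, with no change at the digits printed from compound 2 to compound 4 (within the scatter) between them. Nothing measured here explains the shift. Open, as far as these compounds go, is whether the aromatic ring or its direct attachment to the ring nitrogen matters, which phenyl or pyridin-2-ylmethyl at this place could separate.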